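Aryl amide in place of acetyl on the anilino chalcone

The source may hold more compounds than are shown below. What is called first, only, known or untested is meant among the compounds shown, and "the series" means these compounds.

Compound 3 `COc1cc(/C=C/C(=O)c2cccc(NC(C)=O)c2)ccc1O` carries an acetyl on the ring nitrogen of the shared core. Within the data shown here, in a functional assay on SiHa cells (Homo sapiens) for inhibition (a higher number here means a weaker inhibitor, a lower number a stronger inhibitor), compound 3 gives 15.8 ug/mL, the second highest of the three numbers measured so far. The free amine compound 1 `COc1cc(/C=C/C(=O)c2cccc(N)c2)ccc1O` gives 12.3 ug/mL, and the 2,4-dichlorophenyl amide compound 2 `COc1cc(/C=C/C(=O)c2cccc(NC(=O)c3ccc(Cl)cc3Cl)c2)ccc1O` gives 34.4 ug/mL. The step of a 1.3-fold higher number from compound 1 to compound 3 (0.11 log units; within the scatter) is flat, whereas a 2.8-fold higher number from compound 1 to compound 2 (0.45 log units; beyond the scatter) and a 2.2-fold lower number from compound 2 to compound 3 (0.34 log units; beyond the scatter) show the larger aryl amide sitting modestly higher than both the amine and the acetyl.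

Compound 4 `COc1cc(/C=C/C(=O)c2cccc(NC(=O)c3ccc(Cl)cc3)c2)ccc1O` is not yet measured. Relative to compound 3 the change is 4-chlorophenyl in place of methyl on a carbonyl carbon. The closest measured precedent is a 2.2-fold lower number from compound 2 to compound 3 (0.34 log units; beyond the scatter), run in the opposite direction, though there the aryl group was 2,4-dichlorophenyl rather than 4-chlorophenyl; a 2.8-fold higher number from compound 1 to compound 2 (0.45 log units; beyond the scatter) points the same way. A modest rise in the number is therefore expected, roughly mirroring the precedent, giving an expected step of a 1.6-fold higher number from compound 3 to compound 4 (0.22 log units; within the scatter). Compound 4 is estimated at 26 ug/mL, with a range from 15 ug/mL to 45 ug/mL.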

Compound 4, half-maximal inhibitory concentration: 2.3 ug/mL
For compound 4 the middle estimate is 11-fold (1.05 log units) above the measured one; the measured number lies below the stated range.
By their numbers in this assay, from the lowest: compound 4; then compounds 1 and 3 (each within the scatter of the next); then compound 2.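

In this assay, an aryl group on this carbonyl carbon is not a penalty in itself: a 6.9-fold lower number from compound 3 to compound 4 (0.84 log units; beyond the scatter) and a 5.3-fold lower number from compound 1 to compound 4 (0.73 log units; beyond the scatter) place the 4-chlorophenyl amide clear of both the acetyl amide and the free amine. The 2,4-dichlorophenyl amide goes the other way, and a 15-fold lower number from compound 2 to compound 4 (1.17 log units; beyond the scatter) is a large step for a single chloro replaced by hydrogen, so the substitution on the aryl ring, rather than the presence of the ring, sets the direction of the change. No measurement available for these compounds accounts for this reversal.

As far as these compounds go, whether an unsubstituted phenyl, a 4-fluorophenyl or a 4-methoxyphenyl follows compound 4 or compound 2 remains open. Also open, from the compounds shown here alone, is whether the gain survives replacing the carbonyl with a sulfonyl link.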